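Swapping 4-chlorophenyl for pentyl on compound 1

The compounds below may be only part of what the source reports. "The series", "measured", "known", "first", "only" and "open" are said of these compounds alone.

Measured in a functional assay on A549 cells (Homo sapiens) for antiproliferative activity, read by MTT assay; a lower number here means a stronger inhibitor, a higher number a weaker inhibitor:
- compound 1 `CC1(C)CCc2cc(C(=O)/C=C/c3ccc(OCc4cn(-c5ccc(Cl)cc5)nn4)cc3)c(O)cc2O1`: 75500 nM
- compound 2 `Cc1c(-n2cc(COc3ccc(/C=C/C(=O)c4cc5c(cc4O)OC(C)(C)CC5)cc3)nn2)cccc1[N+](=O)[O-]`: 65900 nM
- compound 3 `CCc1ccccc1-n1cc(COc2ccc(/C=C/C(=O)c3ccc4c(c3O)CCC(C)(C)O4)cc2)nn1`: 112000 nM

Compound 1 cannot be ranked against the other two, since compound 2 and compound 3 each lie within the usual scatter of it. Compound 4 `CCCCCn1cc(COc2ccc(/C=C/C(=O)c3cc4c(cc3O)OC(C)(C)CC4)cc2)nn1` has not yet been measured. It is compound 1 with pentyl in place of 4-chlorophenyl on an aromatic nitrogen.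

One measured step changes the same place, with 2-methyl-3-nitrophenyl in place of 4-chlorophenyl: a 1.1-fold lower number from compound 1 to compound 2 (0.06 log units; within the scatter). Compound 3 differs from compound 1 in more than one place, so it offers no clean comparison. The measured step swaps one ring for another, whereas pentyl has no ring, so no measurement covers this change directly. No direction can be told from the data, and the range must stay wide. The estimated step, a 1.1-fold lower number from compound 1 to compound 4 (0.03 log units; within the scatter), is expected to stay within the scatter. Compound 4 is expected at 70000 nM, with an estimated range of 25000 nM to 160000 nM.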

Compound 4, half-maximal inhibitory concentration: 91300 nM
Compound 4: the middle estimate sits 1.3-fold (0.12 log units) below what was measured; measured number inside the range.
By their numbers in this assay, from the lowest: compounds 2, 1, 4 and 3 (each within the scatter of the next).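

Within the data shown here, until now, only one aromatic ring had stood in for another on this aromatic nitrogen, so it was unknown whether a ring was needed there at all. Pentyl has no ring, yet this assay gives a 1.2-fold higher number from compound 1 to compound 4 (0.08 log units; within the scatter) as the step from the 4-chlorophenyl compound and a 1.4-fold higher number from compound 2 to compound 4 (0.14 log units; within the scatter) as the step from the 2-methyl-3-nitrophenyl compound, so at this position the open chain cannot be told apart from either ring. Nothing at hand gives a reason for this result.

The compounds shown leave open whether any group on this nitrogen can move the number beyond the scatter. A chain ending in an amine or a carboxylic acid, a much longer chain or a single methyl would each test that.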